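A few compounds are considered here, and "the series" means these few. Any claim that something is new, unique, unknown or untested is made for them only; others in the source may bear on it.

Compound 1, `O=S(=O)(Nc1ccc(-c2nc3ccccc3o2)cc1)c1ccc(Cl)s1`: > 100000 nM
Compound 2, `C=Cc1ccc(S(=O)(=O)Nc2ccc3oc(-c4ccccc4)nc3c2)cc1`: 53000 nM

In an ADME assay on HEK293 cells (Homo sapiens) for cytotoxicity, read by resazurin assay, with a stated time of 48 h (on this read-out lower numbers stand for higher toxicity in this test and higher numbers for lower toxicity in this test), compound 1 reports only a limit, > 100000 nM. Going by the values given here, compound 2 gives the single real number in this assay, 53000 nM, so it alone sets a point of reference here. One of the two values is thus (the limit of > 100000 nM in this assay, at which 1 of the 2 values shown sits).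

Compound 3, `O=S(=O)(Nc1ccc2oc(-c3ccccc3)nc2c1)c1ccccc1O`, differs from compound 2 in one place: 2-hydroxyphenyl in place of 4-vinylphenyl on a sulfonyl sulfur. Among the compounds with values here, no measured step of this kind is available to guide the size of change. A modest move toward lower toxicity, or none beyond the usual scatter, is expected, a 1.3-fold higher number from compound 2 to compound 3 (0.12 log units; within the scatter). Compound 3 is therefore estimated at 70000 nM, with a range from 25000 nM to 200000 nM.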

Compound 3, half-maximal cytotoxic concentration: 33000 nM
Compound 3: middle estimate off by 2.1-fold (0.33 log units), on the high side, within the range that was stated.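

In this assay, swapping the 4-vinylphenyl group on the sulfonyl sulfur for a 2-hydroxyphenyl group gives a 1.6-fold lower number from compound 2 to compound 3 (0.21 log units; within the scatter). Going by these compounds alone, this is the first step that can be read at this place, and it does not separate the two groups, although 2-hydroxyphenyl carries a hydrogen-bond donor and a hydrogen-bond acceptor that 4-vinylphenyl lacks. On these data alone, whether an amine or a carboxylic acid on this ring would shift the number beyond the scatter stays open. Compound 1 offers only a limit, not a number, and gives no step to read: the limit of > 100000 nM in this assay, at which 1 of the 3 values shown sits.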